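Compound 3 to compound 4: sulfur group for methylamino

The compounds below may be only part of what the source reports. "The series", "measured", "known", "first", "only" and "open" are said of these compounds alone.

Measured in a functional assay on the whole organism with Rattus norvegicus as the target; a lower number here means that less compound is needed, a higher number that more compound is needed for the effect:
- compound 1 `N=c1sc2cc(OC(F)(F)F)ccc2n1CCS(N)(=O)=O` (6 mg/kg)
- compound 2 `CCCSCCn1c(=N)sc2cc(OC(F)(F)F)ccc21` (2.4 mg/kg)
- compound 3 `CNCCn1c(=N)sc2cc(OC(F)(F)F)ccc21` (limit: > 10 mg/kg)

Compound 3 has no number in this assay and stands only at the limit > 10 mg/kg of that test. Compound 4 `CC[S+]([O-])CCn1c(=N)sc2cc(OC(F)(F)F)ccc21` differs from it by a group of 4 heavy atoms (2 carbon, 1 oxygen, 1 sulfur; no ring) in place of a group of 2 heavy atoms (1 carbon, 1 nitrogen; no ring), on a saturated chain carbon, two bonds along the chain from an aromatic nitrogen at that same chain position.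

All measured steps fall at this position. The step of an at least 4.1-fold higher number from compound 2 to compound 3 (0.61 log units; beyond the scatter) is beyond the scatter, whereas for an at least 1.6-fold higher number from compound 1 to compound 3 (0.22 log units; that floor lies within the scatter) the floor lies within it. Between the two sulfur-bearing groups, a 2.5-fold lower number from compound 1 to compound 2 (0.40 log units; beyond the scatter) is modest. The entering group also contains sulfur, so compound 1 at 6 mg/kg and compound 2 at 2.4 mg/kg are the closest guides.

Expected here is an at least 2.5-fold lower number from compound 3 to compound 4 (0.39 log units; beyond the scatter) in the direction of less compound needed, with its true size left open by the limit. Compound 4 is estimated at 4 mg/kg (expected range 1.5 mg/kg to 10 mg/kg).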

Compound 4, dose for half-maximal effect: 1.2 mg/kg
The estimate for compound 4 lay 3.3-fold (0.52 log units) above the measured number, and the stated range ends above it.
By their numbers in this assay, from the lowest: compounds 4 and 2 (each within the scatter of the next); then compound 1. At a limit, above all of these: compound 3.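

In this assay, the group of 4 heavy atoms (2 carbon, 1 oxygen, 1 sulfur) in place of methylamino gives an at least 8.3-fold lower number from compound 3 to compound 4 (0.92 log units; beyond the scatter), which shows that this position can hold a large gain, with its true size left open. Compound 3 carries only a limit of the test, not a number: the limit of > 10 mg/kg in this assay, at which 1 of the 4 values shown sits. Against propylsulfanyl the same group gives a 2.0-fold lower number from compound 2 to compound 4 (0.30 log units; within the scatter), so the two cannot be told apart, while against sulfamoyl it gives a 5.0-fold lower number from compound 1 to compound 4 (0.70 log units; beyond the scatter), so sulfur in the group does not alone set the number, compound 1 being the sulfur-bearing case that goes against it.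

Still open, from the compounds shown here alone, is how ethylsulfanyl or ethylsulfonyl would compare at this position, which would separate the effect of the oxygen from that of the ethyl chain. Also open, going by these compounds, is whether a longer chain on the sulfur keeps the number.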